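One Aromatic Carbon Varied, Acid Dissociation Expected Unchanged

This account rests on a few compounds, and the source may have more. Where it says the series, first, only, none or still open, it means among the compounds named here.

Three compounds have been measured in a physicochemical assay for acid dissociation:
Compound 1, `COc1ccc(F)cc1CNCCCNc1ccnc2cc(Cc3ccc(F)cc3)ccc12`, gives 9.47.
Compound 2, `COc1ccc(-c2ccc3c(NCCCNCc4cc(F)ccc4OC)ccnc3c2)cc1`, gives 9.47.
Compound 3, `CCC(CC)c1ccc2c(NCCCNCc3cc(F)ccc3OC)ccnc2c1`, gives 9.47.

Compound 3 thus stands level with compound 1 and compound 2 at the digits shown; the step of no change at the digits printed from compound 1 to compound 3 (within the scatter) and the step of no change at the digits printed from compound 2 to compound 3 (within the scatter) are both within the scatter, as is the step of no change at the digits printed from compound 1 to compound 2 (within the scatter). In each of these three pairs the only difference sits on the same aromatic carbon of the shared core, and in none of them did the proton's readiness to leave move beyond the scatter.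

Compound 4, `COc1ccc(F)cc1CNCCCNc1ccnc2cc(CC3CCCCC3)ccc12`, has not yet been measured. It differs from compound 3 at that same place: cyclohexylmethyl in place of pentan-3-yl on an aromatic carbon. The three measured steps all bear on this change, and all were flat, so no step beyond the scatter is expected in this assay. Compound 4 is therefore estimated at 9.47, within the range 9.17 to 9.77. The expected step of no change at the digits printed from compound 3 to compound 4 (within the scatter) is taken to be no change.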

Compound 4, acid dissociation constant: 9.47
Compound 4: middle estimate and measured number agree at the digits printed, within the range that was stated.
By their numbers in this assay, from the lowest: compounds 1, 2, 3 and 4 (each within the scatter of the next).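

In this assay, putting cyclohexylmethyl, with its six-membered non-aromatic ring of carbon only, on this aromatic carbon in place of pentan-3-yl gives no change at the digits printed from compound 3 to compound 4 (within the scatter) and in place of 4-methoxyphenyl gives no change at the digits printed from compound 2 to compound 4 (within the scatter). Exchanging only cyclohexyl for 4-fluorophenyl on the saturated chain carbon bound to that aromatic carbon also gives no change at the digits printed from compound 1 to compound 4 (within the scatter), so among these four compounds a saturated ring at this place reads the same as an aromatic ring or an open branched chain. Nothing available here accounts for this flat result.

The compounds shown leave open whether an amine or a carboxylic acid on this same aromatic carbon would also leave the number level. They also leave open whether a longer chain at this place would do so.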